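Replacing Cyano with Fluoro: Expecting a Lower Number

The compounds below may be only part of what the source reports. "The series", "measured", "known", "first", "only" and "open" are said of these compounds alone.

Within the data shown here, compound 1 `CNC(=O)c1cc(Oc2ccc(C3=NNC(c4ccc(C#N)cc4)C3)cc2)ccn1` gives 15000 nM in a functional assay on HepG2 cells (Homo sapiens) for cytotoxicity, read by MTT assay, with a stated time of 72 h (on this read-out higher numbers stand for weaker inhibition and lower numbers for stronger inhibition), the highest of the two numbers measured so far. Among the measured compounds shown here, compound 2 `CNC(=O)c1cc(Oc2ccc(C3=NNC(c4ccccc4)C3)cc2)ccn1`, which carries a hydrogen in place of the cyano, gives 1500 nM in this assay; the step of a 10-fold lower number from compound 1 to compound 2 (1.00 log units; beyond the scatter) is the only measured step that bears on the present change. Compound 3 `CNC(=O)c1cc(Oc2ccc(C3=NNC(c4ccc(F)cc4)C3)cc2)ccn1` differs from compound 1 by fluoro in place of cyano on an aromatic carbon. For the measured compounds named here, because the one measured step from compound 1, a 10-fold lower number from compound 1 to compound 2 (1.00 log units; beyond the scatter), also removed the cyano and gave a clearly lower number, a lower number in this assay is expected for compound 3 as well, although the size of that step is uncertain and may fall short of what was seen with compound 2. Compound 3 is therefore estimated at 3000 nM, with a range of 1000 nM to 10000 nM, which corresponds to an expected step of a 5.0-fold lower number from compound 1 to compound 3 (0.70 log units; beyond the scatter).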

Compound 3, half-maximal inhibitory concentration: 5280 nM
Estimate against measurement, compound 3: 1.8-fold (0.25 log units) below, and the stated range covers the measured number.
By their numbers in this assay, from the lowest: compound 2; then compound 3; then compound 1.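

The result shows that the lower number in this assay does not depend on hydrogen being what replaces the cyano: with fluoro at this position there is still a 2.8-fold lower number from compound 1 to compound 3 (0.45 log units; beyond the scatter). Fluoro does not, however, match hydrogen on this aromatic carbon, as there is a 3.5-fold higher number from compound 2 to compound 3 (0.55 log units; beyond the scatter), so among these three compounds both substituents give a higher number than hydrogen, and the 4-cyanophenyl compound gives the highest. The data offer no measurement that accounts for this order.

Going by these compounds, whether any group at this position can give a lower number than the hydrogen of compound 2 remains open, as a methoxy, an amine or a carboxylic acid could fall on either side of it. On these data alone, it also remains open whether chloro would stay close to fluoro.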